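The source may report more compounds than this note shows. Statements on the series, on what has been measured and on what is new or still open speak of the compounds shown alone.

Measured so far:
compound 1, `CN(Cc1nc(C2CCN(Cc3ccccc3)CC2)no1)c1ncc(C(=O)NO)cn1`: 63%
compound 2, `Cc1cccc(CN2CCC(c3noc(CN(C)c4ncc(C(=O)NO)cn4)n3)CC2)c1`: 54%

In an assay on isolated protein for inhibition of protein deacetylase HDAC6 (Homo sapiens), read by fluorescence, with a stated time of 1 h, tested at 100 nM (on this read-out higher numbers stand for more inhibition at the one concentration tested (going by the name of the read-out) and lower numbers for less inhibition), compound 2 gives 54%, and compound 1 gives 63%; the one measured step, a number 9 percentage points lower from compound 1 to compound 2 (within the scatter), lies within the scatter, so the two compounds stand together on the numbers shown. Compound 3, `CN(Cc1nc(C2CCN(Cc3ccccc3F)CC2)no1)c1ncc(C(=O)NO)cn1`, differs from compound 2 by 2-fluorophenyl in place of 3-methylphenyl on a saturated chain carbon bound to an amine nitrogen in a ring. Going by the values given here, the measured step bears on it only loosely: the methyl that entered there leaves again here, and a fluorine enters, a change for which no step has been measured. The step is therefore expected to stay within the scatter, a number 4 percentage points higher from compound 2 to compound 3 (within the scatter), and compound 3 is estimated at 58% in this assay, with a range from 40% to 76%.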

Compound 3, a percentage reported as inhibition, at one concentration (the size of the read-out at that concentration, not a potency): 44%
Compound 3: middle estimate off by 14 percentage points, on the high side, and the stated range covers the measured number.
By their numbers in this assay, from the lowest: compounds 3, 2 and 1 (each within the scatter of the next, the first and the last beyond it).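

Going by these compounds alone, the first step beyond the scatter in this assay comes with a single added fluorine (a number 19 percentage points lower from compound 1 to compound 3 (beyond the scatter)), so this position on the benzyl ring does respond to a single-atom change. The swap of 3-methylphenyl for 2-fluorophenyl stays within the scatter (a number 10 percentage points lower from compound 2 to compound 3 (within the scatter)), leaving those two groups together on these numbers. Nothing measured here accounts for the fluoro step. Still open, as far as these compounds go, is how a chloro, methoxy or amino group at this place would read in this assay. Also open, from the compounds shown here alone, is whether the fluoro step holds with a different group in place of the benzyl.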